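The source may hold more compounds than are shown below. What is called first, only, known or untested is meant among the compounds shown, and "the series" means these compounds.

In a physicochemical assay for lipophilicity, read by HPLC, at pH 7.5 (a higher number here means a more lipophilic compound, a lower number a more polar compound), compound 3 `CCOc1ccccc1-c1ccc(-c2nc3cnccc3c(N)c2C#N)cc1` reads 3, the highest of the three numbers available. Compound 2 `CCOc1ccccc1-c1ccc(-c2nc3cnccc3c(N[C@H](CC)C(=O)NS(=O)(=O)C3CC3)c2C#N)cc1` gives 2.3 and compound 1 `N#Cc1c(-c2ccc(Br)cc2)nc2cnccc2c1NCC(N)=O` gives 1.9, both beyond the scatter from compound 3. The next compound, compound 4 `CCOc1ccccc1-c1ccc(-c2nc3cnccc3c(N[C@H](CC)C(=O)O)c2C#N)cc1`, departs from compound 3 by a single change on a nitrogen on an aromatic ring: 1-carboxypropyl in place of hydrogen on a nitrogen on an aromatic ring. In other words, amino becomes (1-carboxypropyl)amino.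

Within the data shown here, only one measured step bears on this change, and it falls at the same nitrogen: a number 0.70 log units higher from compound 2 to compound 3 (beyond the scatter). Read in reverse, this modest step puts the substituted compound on the lower side. Among the measured compounds shown here, it is only a guide, since no measured compound carries 1-carboxypropyl. In this assay, a fall beyond the scatter is therefore expected, of similar or somewhat greater size, though the data cannot fix it closely. The expected change is a number 1.30 log units lower from compound 3 to compound 4 (beyond the scatter). For compound 4 the estimate is 1.7, with an expected range from 1 to 2.3.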

Compound 4, distribution coefficient: 2.1
Estimate against measurement, compound 4: 0.40 log units below; measured number inside the range.
By their numbers in this assay, from the lowest: compounds 1, 4 and 2 (each within the scatter of the next, the first and the last beyond it); then compound 3.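

In this assay the nitrogen on an aromatic ring now has a second measured substituent, 1-carboxypropyl, and its step (a number 0.90 log units lower from compound 3 to compound 4 (beyond the scatter)) falls in the same direction as the one already known at that nitrogen. The other new step (a number 0.20 log units lower from compound 2 to compound 4 (within the scatter)) shows that hydroxy in place of (cyclopropylsulfonyl)amino on a carbonyl carbon stays within the scatter, so the end of this chain does not separate these two substituted compounds here, though both stand apart from compound 3. Nothing at hand gives a reason for either step.

The compounds shown leave open whether a plain propyl on that nitrogen, with no carbonyl, would read like compound 3 or like compound 4. They also leave open what an amine at the end of the chain, in place of the carboxylic acid, would give.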